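The source may hold more compounds than are shown below. What is called first, only, known or untested is meant among the compounds shown, and "the series" means these compounds.

Compounds measured so far:

Compound 1 `COC(=O)C1=C(C)N=C(C)/C(=C(\O)OC)C1c1cccc(N(C)C)c1` — 891 nM
Compound 2 `COC(=O)C1=C(C)N=C(C)/C(=C(\O)OC)C1c1ccccc1I` — 46.8 nM
Compound 3 `COC(=O)C1=C(C)N=C(C)/C(=C(\O)OC)C1c1cc([N+](=O)[O-])ccc1Cl` — 30.2 nM

In a functional assay (muscle tissue) with Cavia porcellus as the target (a lower number here means that less compound is needed, a higher number that more compound is needed for the effect), compound 2 gives 46.8 nM, the second highest of the three numbers. Its nearest neighbour is compound 3, which gives 30.2 nM, a gap within the scatter of the assay, so no order between the two can be claimed. Furthest away is compound 1, which gives 891 nM, a gap well beyond the scatter.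

Compound 4 `COC(=O)C1=C(C)N=C(C)/C(=C(\O)OC)C1c1ccccc1Br` has not yet been measured. It differs from compound 2 in one place: bromo in place of iodo on an aromatic carbon. The difference is a single halogen exchanged for another on an aromatic carbon of the six-membered carbon ring, ortho to a large group.

Going by the values given here, no pair of measured compounds shows this exchange, so the size of the step is unknown. Compound 4 is expected to stay close to compound 2, with a step from compound 2 to compound 4 of a 1.3-fold higher number from compound 2 to compound 4 (0.11 log units; within the scatter) in this assay, most likely within the scatter. Compound 4 is therefore estimated to give 60 nM in this assay, within a range from 25 nM to 150 nM.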

Compound 4, half-maximal effective concentration: 7.59 nM
Beside the measured number, compound 4's estimate is 7.9-fold (0.90 log units) above it, outside the stated range (below it).
By their numbers in this assay, from the lowest: compound 4; then compounds 3 and 2 (each within the scatter of the next); then compound 1.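

Bromo in place of iodo on an aromatic carbon, ortho to a large group, gives a 6.2-fold lower number from compound 2 to compound 4 (0.79 log units; beyond the scatter) in this assay. Going by these compounds alone, this position therefore responds to the exchange of one halogen for another, even though the heavy-atom count stays the same and neither group adds a hydrogen-bond donor or acceptor; the earlier compounds included no pair differing in one place and could not show this. Nothing available bears on the reason for this step.

As far as these compounds go, a single step between two halogens forms no series, so it remains open how chloro, fluoro or a methyl group would compare at this position. From the compounds shown here alone, it also remains open whether the same exchange would give a step of similar size on a ring that also carries a nitro group.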